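From piperidin-3-yl to ethyl on the shared core

This account rests on a few compounds, and the source may have more. Where it says the series, first, only, none or still open, it means among the compounds named here.

Compound 3 `Nc1nc(-c2cc(N3C[C@H](O)[C@@H](O)C3)ccc2O)cc(C2CCCNC2)n1` gives only a limit in a functional assay on A549 cells (Homo sapiens) for cytotoxicity, with a stated time of 48 h (a lower number here means a stronger inhibitor of growth, a higher number a weaker inhibitor of growth), > 10000 nM. Compound 4 `CCc1cc(-c2cc(N3C[C@H](O)[C@@H](O)C3)ccc2O)nc(N)n1` has ethyl in place of piperidin-3-yl on an aromatic carbon. In this assay compound 1 `Nc1nc(-c2cc(N3C[C@H](O)[C@@H](O)C3)ccc2O)cc(C2CCCCC2)n1` gives 1200 nM and compound 2 `Nc1nc(NC2CCCCC2)cc(-c2cc(N3C[C@H](O)[C@@H](O)C3)ccc2O)n1` gives 1500 nM, which is a 1.3-fold higher number from compound 1 to compound 2 (0.10 log units; within the scatter). Two measured steps enter piperidin-3-yl: an at least 8.3-fold higher number from compound 1 to compound 3 (0.92 log units; beyond the scatter) and an at least 6.6-fold higher number from compound 2 to compound 3 (0.82 log units; beyond the scatter). Compound 4 reverses that replacement, but with ethyl instead of cyclohexyl or cyclohexylamino, so a lower number is expected, with only part of those steps recovered. The expected step is an at least 2.0-fold lower number from compound 3 to compound 4 (0.30 log units; that floor lies within the scatter). Compound 4 is estimated at 5000 nM, with an expected range of 1800 nM to 10000 nM.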

Compound 4, concentration for 50% growth inhibition: 3000 nM
The estimate for compound 4 lay 1.7-fold (0.22 log units) above the measured number; the range from low to high includes it.
By their numbers in this assay, from the lowest: compounds 1, 2 and 4 (each within the scatter of the next, the first and the last beyond it). At a limit, above all of these: compound 3.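

In this assay, a ring is not needed at this position for growth inhibition: ethyl, with no ring, gives an at least 3.3-fold lower number from compound 3 to compound 4 (0.52 log units; beyond the scatter). Ethyl separates from only one of the two larger groups, with a 2.5-fold higher number from compound 1 to compound 4 (0.40 log units; beyond the scatter) but a 2.0-fold higher number from compound 2 to compound 4 (0.30 log units; within the scatter). Compound 3 stands at a limit of the assay, and the step out of it is a floor only: the limit of > 10000 nM in this assay, at which 1 of the 4 values shown sits.

Open, going by these compounds, is how the number moves between ethyl and cyclohexyl, which a butyl chain would help to place. Also open, on these data alone, is whether the loss with piperidin-3-yl follows its ring nitrogen, which tetrahydropyran-3-yl, with oxygen in that ring, would address.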